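Carbamate to aryl ether at the hydroxymethyl oxygen

The source may hold more compounds than are shown below. What is called first, only, known or untested is meant among the compounds shown, and "the series" means these compounds.

Compound 2 `COc1nc(C)c(Nc2nc(Cl)cn([C@H](COC(=O)Nc3ccccc3)C3CC3)c2=O)cc1C` gives 1.5 nM in an assay on frontal cortex for displacement of a labelled ligand from corticotropin-releasing factor receptor 1 (Rattus norvegicus), with a stated time of 2 h (a lower number here means a stronger inhibitor, a higher number a weaker inhibitor), the lowest of the three numbers in hand. Compound 3 `COc1nc(C)c(Nc2nc(Cl)cn([C@H](COC(=O)Nc3ccc(Cl)cc3Cl)C3CC3)c2=O)cc1C` gives 1.7 nM, and the step of a 1.1-fold higher number from compound 2 to compound 3 (0.05 log units; within the scatter) lies within the scatter. Compound 1 `COc1nc(C)c(Nc2nc(Cl)cn([C@H](CO)C3CC3)c2=O)cc1C`, the parent with a free hydroxyl, gives 88 nM; the steps of a 59-fold lower number from compound 1 to compound 2 (1.77 log units; beyond the scatter) and a 52-fold lower number from compound 1 to compound 3 (1.71 log units; beyond the scatter) are large. Compound 4 `COc1nc(C)c(Nc2nc(Cl)cn([C@H](COc3cc(Br)ccn3)C3CC3)c2=O)cc1C` differs from compound 2 by 4-bromopyridin-2-yl in place of phenylcarbamoyl on an oxygen on a saturated carbon. For the measured compounds named here, no measured step covers this exchange of a carbamoyl group for a ring attached directly to the oxygen; the measured steps only show that a substituent on that oxygen matters greatly, and that the ring on it tolerates change. Compound 4 is therefore expected to stay well below compound 1 but to give up some of the gain, with an estimated step of a 3.3-fold higher number from compound 2 to compound 4 (0.52 log units; beyond the scatter). Compound 4 is estimated at 5 nM, range 1.5 nM to 20 nM.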

Compound 4, half-maximal inhibitory concentration: 1.5 nM
Beside the measured number, compound 4's estimate is 3.3-fold (0.52 log units) above it; the measured number falls inside the stated range.
By their numbers in this assay, from the lowest: compounds 2, 4 and 3 (each within the scatter of the next); then compound 1.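

In this assay the carbamoyl group is not required on the oxygen on a saturated carbon: no change at the digits printed from compound 2 to compound 4 (within the scatter) and a 1.1-fold lower number from compound 3 to compound 4 (0.05 log units; within the scatter) show that a ring attached directly to that oxygen serves as well, without the hydrogen-bond donor. The gain over the free hydroxyl also holds for this ether, with a 59-fold lower number from compound 1 to compound 4 (1.77 log units; beyond the scatter) on the same scale as the carbamate steps. No evidence available here explains this tolerance.

As far as these compounds go, whether the bromine or the ring nitrogen of 4-bromopyridin-2-yl contributes remains open. So does the outcome for unsubstituted phenyl, pyridin-2-yl or a methyl ether on that oxygen.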